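The source may hold more compounds than are shown below. What is called first, only, known or untested is meant among the compounds shown, and "the series" means these compounds.

Of the compounds shown here, two have been measured in an ADME assay on HEK293 cells (Homo sapiens) for cytotoxicity, read by ATP content, with a stated time of 6 h; a lower number here means that less compound is tolerated, a higher number that more compound is tolerated: compound 1 (`CCCCNc1nc(N)nc2ccn(Cc3ncccc3OC)c12`) and compound 2 (`CCOCCNc1nc(N)nc2ccn(Cc3ccccn3)c12`). Compound 1 reads > 24000 nM, which is a limit of the assay and not a number. Compound 2 reads > 24000 nM, which is likewise only a limit. For the measured compounds named here, the record therefore comes down to the limit of > 24000 nM in this assay, at which 2 of the 2 values shown sit, and it contains no measured step between compounds that differ in one place.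

Compound 3 (`Cc1coc(CNc2nc(N)nc3ccn(Cc4ccccn4)c23)n1`) has not yet been measured. It keeps the shared core of compound 2 but changes the 2-ethoxyethyl group to (4-methyl-1,3-oxazol-2-yl)methyl, so that 4-methyl-1,3-oxazol-2-yl takes the place of ethoxymethyl on a saturated chain carbon bound to a nitrogen on an aromatic ring: 4-methyl-1,3-oxazol-2-yl in place of ethoxymethyl on a saturated chain carbon bound to a nitrogen on an aromatic ring.

No number in this assay yet shows how far such a change can move the result, and no shift beyond the usual scatter is expected in either direction. The expected step is an at least 1.0-fold lower number from compound 2 to compound 3 (0.03 log units; that floor lies within the scatter). A further limit is the likeliest report. If a number is returned, the estimate for compound 3 is 22000 nM, with an expected range from 10000 nM to 30000 nM.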

Compound 3, half-maximal cytotoxic concentration: > 24000 nM
Compound 3 gave a limit, no number (the forecaster's own chance of this, stated with the estimate: 80%); middle value at least 1.0-fold (0.03 log units) away from the limit.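

In this assay compound 3 gives > 24000 nM, which is a limit and not a number. Compound 2 also reads as a limit, so no step can be read between compound 2 and compound 3. The compounds shown leave open how far any change moves the half-maximal cytotoxic concentration, since the record rests on a single value: the limit of > 24000 nM in this assay, at which 3 of the 3 values shown sit.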